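Dihydroxyphenyl in place of chlorophenyl on a chalcone

The source may hold more compounds than are shown below. What is called first, only, known or untested is meant among the compounds shown, and "the series" means these compounds.

Measured compounds:
compound 1, `COc1cc(OC)c(OC)cc1/C=C/C(=O)c1ccc(Cl)cc1`: 2.3 ug/mL
compound 2, `COc1cc(OC)c(-c2cc(=O)c3ccc(O)cc3o2)cc1OC`: 2.15 ug/mL

Of the compounds shown here, two have been measured in a functional assay on cells (Erythrocyte, Rattus norvegicus) for inhibition, read by hemolysis, with a stated time of 1 h; a higher number here means a weaker inhibitor, a lower number a stronger inhibitor. Compound 1 gives 2.3 ug/mL and compound 2 gives 2.15 ug/mL. The number for compound 1 is the higher of the two, yet the two values lie within the usual scatter of each other, so no order between them can be drawn. Compound 3, `COc1cc(OC)c(OC)cc1/C=C/C(=O)c1ccc(O)cc1O`, has not been measured. It differs from compound 1 in one place: 2,4-dihydroxyphenyl in place of 4-chlorophenyl on a carbonyl carbon. Going by the values given here, no step between measured compounds shows what this change does, so only a modest shift is expected in this assay, possibly none beyond the scatter. For compound 3 the expected value is 3 ug/mL, between 1 ug/mL and 9 ug/mL. The expected step is a 1.3-fold higher number from compound 1 to compound 3 (0.12 log units; within the scatter).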

Compound 3, half-maximal inhibitory concentration: 2.37 ug/mL
Compound 3: middle estimate off by 1.3-fold (0.10 log units), on the high side; the measured number falls inside the stated range.
By their numbers in this assay, from the lowest: compounds 2, 1 and 3 (each within the scatter of the next).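

In this assay, placing 2,4-dihydroxyphenyl in place of 4-chlorophenyl on the carbonyl carbon gives a 1.0-fold higher number from compound 1 to compound 3 (0.01 log units; within the scatter). This first readable step at this position shows that a ring carrying two hydrogen-bond donors and a ring carrying none cannot be told apart in this read-out. Nothing available explains this result. Going by these compounds, what remains open is whether an amine or a carboxylic acid on this ring would move the number beyond the scatter. Also open, on these data alone, is whether either hydroxyl alone would give the same result.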